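A few compounds are considered here, and "the series" means these few. Any claim that something is new, unique, unknown or untested is made for them only; others in the source may bear on it.

Measured compounds:
compound 1, `O=C(NCCCCc1ccccc1)n1c(=O)oc2ccccc21`: 64 nM
compound 2, `O=C(NCCCCCc1ccccc1)n1c(=O)oc2ccccc21`: 54 nM

In an assay on HEK293 cells for inhibition of acid ceramidase (Homo sapiens), with a stated time of 10 min (a higher number here means a weaker inhibitor, a lower number a stronger inhibitor), compound 1 gives the higher of the two numbers, though the step of a 1.2-fold lower number from compound 1 to compound 2 (0.07 log units; within the scatter) lies within the scatter. Compound 3, `O=C(NCCCCc1ccccc1)n1c(=O)oc2c(Br)cccc21`, keeps the chain of compound 1 and alters the shared core: bromo in place of hydrogen on an aromatic carbon. Going by the values given here, no measured step touches the core; the one recorded step, a 1.2-fold lower number from compound 1 to compound 2 (0.07 log units; within the scatter), concerns the chain only and gives no guide here. No step beyond the scatter is therefore expected in this assay. Compound 3 is estimated at 60 nM (20 nM to 200 nM), expected as a step of a 1.1-fold lower number from compound 1 to compound 3 (0.03 log units; within the scatter).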

Compound 3, half-maximal inhibitory concentration: 18 nM
Estimate against measurement, compound 3: 3.3-fold (0.52 log units) above; measured number below the stated range.
By their numbers in this assay, from the lowest: compound 3; then compounds 2 and 1 (each within the scatter of the next).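

In this assay bromo in place of hydrogen on an aromatic carbon gives a 3.6-fold lower number from compound 1 to compound 3 (0.55 log units; beyond the scatter) and so shows that the shared core, not only the chain, can shift this number. The earlier step of a 1.2-fold lower number from compound 1 to compound 2 (0.07 log units; within the scatter) concerned the chain alone and stayed within the scatter. Nothing measured here accounts for the effect of bromo at this position.

Open, from the compounds shown here alone, is whether chloro, fluoro or methoxy on the same aromatic carbon would give a similar step. Also open, going by these compounds, is whether bromo would give a similar step on the chain of compound 2.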